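Working notes on three measured compounds and a fourth

The source may hold more compounds than are shown below. What is called first, only, known or untested is meant among the compounds shown, and "the series" means these compounds.

Measured in an assay on CHO cells for displacement of a labelled ligand from adenosine receptor A1 (Homo sapiens), read by scintillation counting, tested at 10 uM; a higher number here means more inhibition at the concentration tested (going by the name of the read-out), a lower number less inhibition:
compound 1 `CC(C)(C)Cc1csc(N)c1C(=O)c1cccc(Cl)c1`: 2%
compound 2 `CC(C)(C)Cc1c(Br)sc(N)c1C(=O)c1cccc(Cl)c1`: 1%
compound 3 `CC(C)(C)Cc1c(-c2ccccc2)sc(N)c1C(=O)c1cccc(Cl)c1`: 2%

Compound 3 stands level with compound 1, the two together the highest of the three numbers; its nearest neighbour is compound 1, with no change at the digits printed from compound 1 to compound 3 (within the scatter), its furthest compound 2, with a number 1 percentage points higher from compound 2 to compound 3 (within the scatter). All three values sit near the floor of this assay.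

Compound 4 `CC(C)(C)Cc1c(-c2ccccc2)sc(N)c1C(=O)c1ccc(Cl)cc1Cl` is not yet measured. It differs from compound 3 in one place: 2,4-dichlorophenyl in place of 3-chlorophenyl on a carbonyl carbon.

Within the data shown here, no measured step touches that ring. The three measured steps all change a substituent on an aromatic carbon of the shared core: a number 1 percentage points lower from compound 1 to compound 2 (within the scatter), no change at the digits printed from compound 1 to compound 3 (within the scatter) and a number 1 percentage points higher from compound 2 to compound 3 (within the scatter), each within the scatter. The data therefore give no direction for the change to compound 4, and the expectation is a step of a number 1 percentage points higher from compound 3 to compound 4 (within the scatter), none beyond the scatter. Compound 4 is estimated at 3%, within a range of -5% to 15%.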

Compound 4, a percentage reported as inhibition, at one concentration (the size of the read-out at that concentration, not a potency): 1%
The estimate for compound 4 lay 2 percentage points above the measured number; measured number inside the range.
By their numbers in this assay, from the lowest: compounds 2, 4, 1 and 3 (each within the scatter of the next).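

Among these compounds, exchanging the ring on the carbonyl carbon, which no earlier step touched, gives a number 1 percentage points lower from compound 3 to compound 4 (within the scatter) in this assay. Replacing 3-chlorophenyl with 2,4-dichlorophenyl therefore leaves the number near the assay floor, as did the substituent changes on the shared core. Nothing available explains this result.

Still open, from the compounds shown here alone, is whether any other group at this place moves the number beyond the scatter, for example an amine or a carboxylic acid on the ring. With all values near the floor, these compounds cannot show which features of the series matter for this receptor.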